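A few compounds are considered here, and "the series" means these few. Any claim that something is new, unique, unknown or untested is made for them only; others in the source may bear on it.

Compound 1 `Cc1ccnc(/C(N)=N/NC(=S)N2CCOCC2)c1` gives 33.6% in a functional assay on A-431 cells (Homo sapiens) for cytotoxicity, read by MTT assay, with a stated time of 72 h, tested at 1 uM; a lower number here means less inhibition of growth, a higher number more inhibition of growth at the concentration tested.
Compound 2 `N/C(=N\NC(=S)N1CCCC1)c1ccccn1` gives 39.8% in this assay.
Compound 3 `Cc1ccnc(/C(N)=N/NC(=S)N2CCCCC2)c1` gives 31.1% in this assay.

Compound 3 holds the lowest of these three numbers, but its distance to compound 1 lies within the scatter, and so does its distance to compound 2, which is the furthest of the three; the three values therefore cannot be told apart. Going by the values given here, the only single-point step among the measured compounds, a number 2.5 percentage points lower from compound 1 to compound 3 (within the scatter), is within the scatter as well.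

Compound 4 `Cc1ccnc(/C(N)=N/NC(=S)N2CCCC2)c1` has not been measured in this assay. It arises from compound 3 by pyrrolidin-1-yl in place of piperidin-1-yl on a thiocarbonyl carbon. Among the compounds with values here, the step from compound 1 to compound 3 is the only measured change at that place, and it left the number where it was. Compound 2 also carries pyrrolidin-1-yl on the thiocarbonyl carbon, but its core differs from that of compound 4 in another place, so its value only shows that this ring sits in the same band of numbers as the others. The step from compound 3 to compound 4 is therefore expected to be a number 3.9 percentage points higher from compound 3 to compound 4 (within the scatter), not beyond the scatter. Compound 4 is expected to give about 35%, in a range from 22% to 48%.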

Compound 4, percent growth inhibition at one concentration: 58.5%
Estimate against measurement, compound 4: 23.5 percentage points below; measured number above the stated range.
By their numbers in this assay, from the lowest: compounds 3, 1 and 2 (each within the scatter of the next); then compound 4.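

In this assay, the ring on the thiocarbonyl carbon turns out not to be interchangeable on the shared core: pyrrolidin-1-yl stands apart from piperidin-1-yl (a number 27.4 percentage points higher from compound 3 to compound 4 (beyond the scatter)) and from morpholin-4-yl (a number 24.9 percentage points higher from compound 1 to compound 4 (beyond the scatter)), although the change between those two six-membered rings stayed within the scatter. Pyrrolidin-1-yl does not produce the higher number by itself, since methyl in place of hydrogen on an aromatic carbon also matters when this ring is present (a number 18.7 percentage points higher from compound 2 to compound 4 (beyond the scatter)), and among these compounds only compound 4 carries both features. Nothing available accounts for either step, so the reason for these differences remains unknown.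

The compounds shown leave open whether the number on the thiocarbonyl carbon would hold or change with azetidin-1-yl or an open-chain dimethylamino group in place of pyrrolidin-1-yl. They also leave open whether ethyl, methoxy or chlorine could stand in for the methyl on the aromatic carbon while keeping the growth inhibition seen with compound 4.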